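Urea substituent size on the shared sulfonate core

The compounds below may be only part of what the source reports. "The series", "measured", "known", "first", "only" and "open" are said of these compounds alone.

Compound 3 `CCCCCNC(=O)Nc1ccc(S(=O)(=O)Oc2ccccc2I)cc1` carries a pentyl group on the urea nitrogen. Going by the values given here, in a functional assay on MCF7 cells (Homo sapiens) for antiproliferative activity, read by sulforhodamine B assay, with a stated time of 48 h (on this read-out lower numbers stand for stronger inhibition and higher numbers for weaker inhibition), compound 3 gives 5400 nM, the second highest of the three numbers measured so far. Its nearest neighbour is compound 1 `O=C(CCCCl)Nc1ccc(S(=O)(=O)Oc2ccccc2I)cc1`, which in this assay gives 6300 nM; the two values lie within the scatter of each other. The furthest is compound 2 `CCNC(=O)Nc1ccc(S(=O)(=O)Oc2ccccc2I)cc1`, which in this assay gives 1100 nM; a 4.9-fold higher number from compound 2 to compound 3 (0.69 log units; beyond the scatter).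

Compound 4 `O=C(Nc1ccc(S(=O)(=O)Oc2ccccc2I)cc1)NC1CC1` differs from compound 3 by cyclopropyl in place of pentyl on an amide-type nitrogen. The step that bears on this is the chain extension from compound 2 to compound 3, in which a 4.9-fold higher number from compound 2 to compound 3 (0.69 log units; beyond the scatter); the change to compound 4 runs the other way, replacing the pentyl group by a three-carbon ring closer in size to the ethyl group of compound 2. The steps of a 5.7-fold lower number from compound 1 to compound 2 (0.76 log units; beyond the scatter) and a 1.2-fold lower number from compound 1 to compound 3 (0.07 log units; within the scatter) give the same picture: the smaller urea substituent goes with the lower number. No ring-bearing substituent has been measured in this series, so the expectation rests only on size.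

Compound 4 is therefore expected to give a lower number in this assay, estimated at 1800 nM with a range of 700 nM to 5000 nM, meaning a 3.0-fold lower number from compound 3 to compound 4 (0.48 log units; beyond the scatter).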

Compound 4, half-maximal inhibitory concentration: 7400 nM
For compound 4 the middle estimate is 4.1-fold (0.61 log units) below the measured one, and the stated range ends below it.
By their numbers in this assay, from the lowest: compound 2; then compounds 3, 1 and 4 (each within the scatter of the next).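

In this assay, the ring does not behave like the small chain: with cyclopropyl on the amide-type nitrogen, the series shows a 6.7-fold higher number from compound 2 to compound 4 (0.83 log units; beyond the scatter), whereas the change from pentyl gives a 1.4-fold higher number from compound 3 to compound 4 (0.14 log units; within the scatter). Fewer heavy atoms in the urea substituent therefore do not by themselves go with the lower number, and compound 4 goes against the size trend suggested by compounds 1, 2 and 3; alongside a 1.2-fold higher number from compound 1 to compound 4 (0.07 log units; within the scatter), this leaves compound 2, with its ethyl group, as the only compound set apart from the other three. Nothing available accounts for the separation between the ethyl and cyclopropyl groups at this position.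

The compounds shown leave open whether methyl, propyl or butyl on the same nitrogen would stay with compound 2 or join the other three, and so how narrowly the lower number is tied to ethyl. They also leave open whether isopropyl or cyclobutyl would match compound 4, which would help separate the presence of a ring or branch from chain length.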